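Swapping the aryl ether of a quinoxaline diamine for a thioether

The source may hold more compounds than are shown below. What is called first, only, known or untested is meant among the compounds shown, and "the series" means these compounds.

This account follows a single change made to compound 1, whose structure is `Nc1cc(N)c2nc(-c3ccccc3)c(Oc3ccc(Cl)c(Cl)c3)nc2c1`. In a functional assay on SK-OV-3 cells (Homo sapiens) for inhibition, read by sulforhodamine B assay, with a stated time of 48 h (on this read-out higher numbers stand for weaker inhibition of growth and lower numbers for stronger inhibition of growth), compound 1 gives 24000 nM. Compound 3, `CCOC(=O)[C@H](CCC(=O)O)NC(=O)c1ccc(Oc2nc3cc(N)cc(N)c3nc2-c2ccccc2)cc1`, carries a larger ester-bearing side chain on the same core and gives 28200 nM in this assay, a value that sits within the usual scatter of the number for compound 1, so the two cannot be told apart. Compound 2, `CCOC(=O)[C@H](CCC(=O)O)NC(=O)c1ccc(CNc2nc3cc(N)cc(N)c3nc2-c2ccccc2)cc1`, reports only a limit in this assay, < 100000 nM, and no number; that is the situation described by the limit of < 100000 nM in this assay, at which 1 of the 3 values shown sits. Among the two numbers that are known, compound 1 holds the lower one, with compound 3 close beside it.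

The new compound, compound 4, has the structure `Nc1cc(N)c2nc(-c3ccccc3)c(Sc3ccc(F)cc3)nc2c1`. It differs from compound 1 by (4-fluorophenyl)sulfanyl in place of 3,4-dichlorophenoxy on an aromatic carbon; that is, (4-fluorophenyl)sulfanyl takes the place of 3,4-dichlorophenoxy on an aromatic carbon of the shared core. Among the compounds with values here, no measured pair here isolates such a change, so there is nothing in the data to anchor a direction. The expectation for the step from compound 1 to compound 4 in this assay is therefore a 1.1-fold lower number from compound 1 to compound 4 (0.04 log units; within the scatter), that is, no move beyond the scatter. Compound 4 is accordingly estimated at 22000 nM, within a range from 7000 nM to 70000 nM.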

Compound 4, concentration for 50% growth inhibition: 15800 nM
Compound 4: the middle estimate sits 1.4-fold (0.14 log units) above what was measured; measured number inside the range.
By their numbers in this assay, from the lowest: compounds 4, 1 and 3 (each within the scatter of the next).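

Within the data shown here, at the aromatic carbon next to the ring nitrogen of the shared core, placing (4-fluorophenyl)sulfanyl where 3,4-dichlorophenoxy stood gives a 1.5-fold lower number from compound 1 to compound 4 (0.18 log units; within the scatter) in this assay, the first step at this position that can be read from two numbers. The step shows that the growth-inhibition value stays within the scatter when the aryl group is exchanged at this carbon, with both the atom linking the ring to the core and the halogens on that ring differing between compound 1 and compound 4, so this position accepts at least this one exchange without a change that can be told from the scatter. Nothing measured here speaks to a cause for this outcome.

The compounds shown leave open how much of the step belongs to the linking atom and how much to the halogens, since the two differ together and no pair separates them. They also leave open what a sulfonyl link, or a morpholine set directly on this carbon in place of the aryl group, would do to the value.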